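This account rests on a few compounds, and the source may have more. Where it says the series, first, only, none or still open, it means among the compounds named here.

Compound 1 `Oc1ccc(O)c(-c2cc(-c3ccc(Cl)cc3)nn2-c2ccccc2)c1` — 3430 nM
Compound 2 `NS(=O)(=O)c1ccc(-n2nc(-c3ccc(Cl)cc3)cc2-c2cc(O)ccc2O)cc1` — 5030 nM

In a functional assay on cells (Leukemia cell, Homo sapiens) for cytotoxicity, read by sulforhodamine B assay, with a stated time of 48 h (a higher number here means a weaker inhibitor of growth, a lower number a stronger inhibitor of growth), compound 1 gives 3430 nM. In this assay compound 2 gives 5030 nM, the higher of the two numbers, yet a 1.5-fold higher number from compound 1 to compound 2 (0.17 log units; within the scatter), so the two compounds cannot be told apart on these numbers.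

The next compound, compound 3 `CC(=O)NS(=O)(=O)c1ccc(-n2nc(-c3ccc(Cl)cc3)cc2-c2cc(O)ccc2O)cc1`, differs from compound 2 in one place: acetyl in place of hydrogen on a sulfonamide nitrogen. The acetyl group enters on the very sulfamoyl group that distinguished compound 2 from compound 1. That single step is the only one measured, and it stayed within the scatter. Going by the values given here, no measured pair shows an acetyl entering on a sulfonamide nitrogen, so there is no direct guide. Among the compounds with values here, with the one related step having moved nothing beyond the scatter, compound 3 is expected to give about 5000 nM, between 2000 nM and 12500 nM, the estimated step being a 1.0-fold lower number from compound 2 to compound 3 (0.00 log units; within the scatter).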

Compound 3, concentration for 50% growth inhibition: 37400 nM
The estimate for compound 3 lay 7.5-fold (0.87 log units) below the measured number, and the stated range ends below it.
By their numbers in this assay, from the lowest: compounds 1 and 2 (each within the scatter of the next); then compound 3.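

In this assay the sulfonamide nitrogen proves to be a place where a change can be seen (acetyl in place of hydrogen gives a 7.4-fold higher number from compound 2 to compound 3 (0.87 log units; beyond the scatter)), whereas the sulfamoyl group alone had stayed within the scatter. Measured against compound 1, which carries hydrogen on that aromatic carbon, the whole acetylsulfamoyl group gives an 11-fold higher number from compound 1 to compound 3 (1.04 log units; beyond the scatter), so among these three compounds growth inhibition weakens clearly only once the acetyl is present. Nothing available here explains why this acetyl group weakens growth inhibition.

Going by these compounds, it remains open whether this loss belongs to the acetyl group itself or would also follow from a methyl, a propionyl or a benzoyl group on the same nitrogen. On these data alone, it is equally open how a carboxylic acid or an amine would compare with the sulfamoyl group on that aromatic carbon.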